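The source may report more compounds than this note shows. Statements on the series, on what has been measured and on what is new or still open speak of the compounds shown alone.

Compound 3, `Cc1cc(NCc2ccccn2)n2ncc(-c3ccc(N(C)C)cc3)c2n1`, has been tested in a physicochemical assay for solubility, read by HPLC, using the shake flask method, measured as kinetic solubility, with a stated time of 2 h, at pH 7.4; on this read-out lower numbers stand for lower solubility and higher numbers for higher solubility. In this assay compound 3 gives only a limit, < 5000 nM, and not a number. Two related compounds sit at the same place. Compound 1, `Cc1cc(NCc2ccccn2)n2nc(C)c(-c3ccc(F)cc3)c2n1`, gives in this assay a limit, < 5000 nM. Compound 2, `Cc1cc(NCc2ccc3ccccc3n2)n2nc(C)c(-c3ccccc3)c2n1`, gives in this assay a limit, < 5000 nM. So every measured value here is a limit rather than a number, as the limit of < 5000 nM in this assay, at which 3 of the 3 values shown sit, shows, and compound 3 stands no higher and no lower than the rest on what has been read.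

Compound 4, `Cc1cc(NCc2ccccn2)n2ncc(-c3ccc(O)cc3)c2n1`, has not yet been measured. It differs from compound 3 in one place: hydroxy in place of dimethylamino on an aromatic carbon. Going by the values given here, no measured pair of compounds differs by a single change, so there is no measured step of this kind to lean on. Because the limit of < 5000 nM in this assay, at which 3 of the 3 values shown sit, holds for all three compounds seen so far, compound 4 is expected to sit close to that limit as well. The step that the limit leaves unreadable from compound 3 to compound 4 is expected to be small, within the usual scatter, with no clear direction. Compound 4 is expected to give about 3000 nM, somewhere between 500 nM and 20000 nM, and it is likely that this assay will again report only a limit for compound 4.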

Compound 4, solubility: 10900 nM
Beside the measured number, compound 4's estimate is 3.6-fold (0.56 log units) below it; measured number inside the range.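

In this assay, compound 4 is the first compound shown to give a number rather than a limit, so this carbon of the six-membered aromatic ring is a place where one change can lift a compound clear of the limit. Moving from 4-(dimethylamino)phenyl to 4-hydroxyphenyl, with the rest of the structure unchanged, goes with an at least 2.1-fold higher number from compound 3 to compound 4 (0.33 log units; beyond the scatter), a step beyond the usual scatter of this kind of measurement. The true size of that step stays unknown and could be larger, because the reading for compound 3 is a limit and only compound 4 supplies a number: the limit of < 5000 nM in this assay, at which 3 of the 4 values shown sit.

As far as these compounds go, this single pair cannot separate what the arrival of hydroxy contributes from what the loss of dimethylamino contributes, and how a methoxy group, an amine or a carboxylic acid on the same carbon would read remains open. From the compounds shown here alone, it is also open whether the same change would give a similar step in a compound with a different core or side chain, such as compound 1 or compound 2.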